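Methoxy in Place of Bromo: Three Measured, One Expected

A few compounds are considered here, and "the series" means these few. Any claim that something is new, unique, unknown or untested is made for them only; others in the source may bear on it.

Compound 1 `CN(c1ccc2[nH]c(-c3n[nH]c4ccccc34)cc2n1)S(=O)(=O)c1ccccc1`: 14000 nM
Compound 2 `Cc1ccc(S(=O)(=O)N(C)c2ccc3[nH]c(-c4n[nH]c5ccccc45)cc3n2)cc1`: 27100 nM
Compound 3 `CN(c1ccc2[nH]c(-c3n[nH]c4ccccc34)cc2n1)S(=O)(=O)c1ccc(Br)cc1`: 19700 nM

Three compounds sharing one core were measured in a functional assay on A549 cells (Homo sapiens) for antiproliferative activity, read by MTT assay, with a stated time of 72 h; a higher number here means a weaker inhibitor, a lower number a stronger inhibitor. Compound 1 gives 14000 nM, compound 2 gives 27100 nM and compound 3 gives 19700 nM. Compound 3 stands second highest of the three numbers; its nearest neighbour is compound 2, with a 1.4-fold lower number from compound 2 to compound 3 (0.14 log units; within the scatter), and its furthest is compound 1, with a 1.4-fold higher number from compound 1 to compound 3 (0.15 log units; within the scatter). All three values sit within the scatter of one another, so no order among them can be read.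

Compound 4 `COc1ccc(S(=O)(=O)N(C)c2ccc3[nH]c(-c4n[nH]c5ccccc45)cc3n2)cc1` has not yet been measured. It differs from compound 3 by methoxy in place of bromo on an aromatic carbon. Among the measured compounds shown here, the steps that bear on this change are those at the same position: a 1.9-fold higher number from compound 1 to compound 2 (0.29 log units; within the scatter) and a 1.4-fold higher number from compound 1 to compound 3 (0.15 log units; within the scatter), both within the scatter. Two different groups at this position therefore left this assay essentially unchanged, and the same is expected for a methoxy group there. The step of a 1.0-fold higher number from compound 3 to compound 4 (0.01 log units; within the scatter) is accordingly expected to be small, with no direction beyond the scatter. Compound 4 is estimated to give 20000 nM, with a range from 10000 nM to 40000 nM.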

Compound 4, half-maximal inhibitory concentration: 24300 nM
Compound 4: the middle estimate sits 1.2-fold (0.08 log units) below what was measured; low and high end bracket the measured number.
By their numbers in this assay, from the lowest: compounds 1, 3, 4 and 2 (each within the scatter of the next).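

In this assay, the change from bromo to methoxy gives a 1.2-fold higher number from compound 3 to compound 4 (0.09 log units; within the scatter), so the hydrogen-bond acceptor counted for methoxy, and absent from bromo, produces no difference that can be read at this place on the six-membered aromatic ring. The other two new steps, a 1.1-fold lower number from compound 2 to compound 4 (0.05 log units; within the scatter) and a 1.7-fold higher number from compound 1 to compound 4 (0.24 log units; within the scatter), also stay within the scatter, so methoxy joins hydrogen, methyl and bromo as a fourth substituent state that cannot be told apart from the others in this assay. No measurement shown offers an explanation for this lack of separation.

The four compounds leave open whether any group at this place can move the number beyond the scatter, for example an amine, a carboxylic acid or a longer chain. They also leave open how this assay responds to changes elsewhere, since the shared core and the methyl group on the sulfonamide nitrogen are the same in compound 1, compound 2, compound 3 and compound 4.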